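From 3,4-dihydroxyphenyl to 4-hydroxyphenyl on the shared core

The source may report more compounds than this note shows. Statements on the series, on what has been measured and on what is new or still open speak of the compounds shown alone.

Within the data shown here, in a functional assay on SW-620 cells (Homo sapiens) for cytotoxicity (on this read-out higher numbers stand for weaker inhibition of growth and lower numbers for stronger inhibition of growth), compound 2 (`CSc1ccc(C2=C(c3ccc(O)c(O)c3)C(=O)N3CCCC3C2)cc1`) gives 50000 nM, the higher of the two numbers so far. Compound 1 (`COc1ccc(C2=C(c3ccc(SC)cc3)CC3CCCN3C2=O)cc1C`) gives 500 nM in this assay on the same core. Among the measured compounds shown here, the one measured step, a 100-fold higher number from compound 1 to compound 2 (2.00 log units; beyond the scatter), came with 3,4-dihydroxyphenyl in place of 4-methoxy-3-methylphenyl on a double-bonded ring carbon.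

Compound 3 (`CSc1ccc(C2=C(c3ccc(O)cc3)C(=O)N3CCCC3C2)cc1`) has hydrogen in place of hydroxy on an aromatic carbon, ortho to a hydroxy group and meta to a large group: hydrogen in place of hydroxy on an aromatic carbon. The result is a 4-hydroxyphenyl group. For the measured compounds named here, no measured pair isolates this change, and only the step from compound 1 bears on it, and only loosely. Compound 3 retains one hydroxy group and lacks the methoxy and methyl groups of compound 1, so only part of a 100-fold higher number from compound 1 to compound 2 (2.00 log units; beyond the scatter) is expected to be reversed. The expected change is an 8.3-fold lower number from compound 2 to compound 3 (0.92 log units; beyond the scatter), a moderate move toward a lower number. For compound 3 the estimated value is 6000 nM, with an expected range from 1200 nM to 30000 nM.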

Compound 3, concentration for 50% growth inhibition: > 100000 nM
Compound 3 was reported as a limit; the forecaster's own chance of this, stated with the estimate: 15%; middle value at least 16-fold (1.22 log units) away from the limit.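

In this assay compound 3 gives > 100000 nM, which is a limit of the assay and not a number: the limit of > 100000 nM in this assay, at which 1 of the 3 values shown sits.

Removing the hydroxy group that sat ortho to a hydroxy group and meta to a large group brought no lower number, giving an at least 2.0-fold higher number from compound 2 to compound 3 (0.30 log units; that floor lies within the scatter), so the size of this step stays undetermined and the two compounds cannot be ordered beyond the scatter. The new comparison with the methoxy and methyl compound gives an at least 200-fold higher number from compound 1 to compound 3 (2.30 log units; beyond the scatter), which shows that the large gap seen with 3,4-dihydroxyphenyl persists with 4-hydroxyphenyl and does not depend on the second hydroxy group.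

The compounds shown leave open whether the methoxy group, the methyl group or both account for the much lower number of compound 1, since a 4-methoxyphenyl or a 3-methylphenyl group on this carbon would be needed to separate them. They also leave open how an amine or a carboxylic acid at this place on the ring would read in this assay, and how far compound 3 actually lies from compound 2.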